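A few compounds are considered here, and "the series" means these few. Any claim that something is new, unique, unknown or untested is made for them only; others in the source may bear on it.

Working notes on the series in a functional assay on the whole organism for inhibition, with Chenopodium ficifolium as the target, with a stated time of 72 h, tested at 10 mg/L; a lower number here means less inhibition of growth, a higher number more inhibition of growth at the concentration tested.

Compound 1 `Cc1onc(-c2ccc(Cl)cc2Cl)c1C(=O)/N=c1/nc2nc(Cl)cc(C)n2s1` gives 18.6% in this assay. Among the three measured compounds it stands second highest; the nearest neighbour is compound 2 `Cc1cc(C)nc(NC(=S)NC(=O)c2c(-c3ccc(Cl)cc3Cl)noc2C)n1`, which gives 16.9%, a gap within the scatter, and the furthest is compound 3 `COc1cc(OC)nc(NC(=S)NC(=O)c2c(-c3ccc(Cl)cc3Cl)noc2C)n1`, which gives 30.7%, a gap beyond the scatter.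

Compound 4 `COc1cc(Cl)nc2n/c(=N/C(=O)c3c(-c4ccc(Cl)cc4Cl)noc3C)sn12` is not yet measured. It differs from compound 1 in one place: methoxy in place of methyl on an aromatic carbon, the carbon carrying it next to the ring nitrogen, ortho to a fused ring, meta to a chloro group, meta to a fused ring and opposite the ring nitrogen.

Within the data shown here, the only measured step that bears on this change is the one on the open-chain pair, a number 13.8 percentage points higher from compound 2 to compound 3 (beyond the scatter), where two methyls give way to two methoxy groups on a six-membered aromatic ring with two nitrogens. Compound 4 carries one such exchange on a fused core rather than two on an open one, so a smaller shift of the same sign is expected. For compound 4 the expected step is a number 7.4 percentage points higher from compound 1 to compound 4 (within the scatter). Compound 4 is therefore estimated at 26%, with a range from 14% to 38%, the lower end overlapping the values of compound 1 and compound 2 within the scatter.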

Compound 4, percent growth inhibition at one concentration: 19.3%
Beside the measured number, compound 4's estimate is 6.7 percentage points above it, and the stated range covers the measured number.
By their numbers in this assay, from the lowest: compounds 2, 1 and 4 (each within the scatter of the next); then compound 3.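

In this assay, methoxy in place of methyl on an aromatic carbon of the shared core gives a number 0.7 percentage points higher from compound 1 to compound 4 (within the scatter), so this position shows no measurable response to the exchange at the concentration tested. The open-chain pair gave a number 13.8 percentage points higher from compound 2 to compound 3 (beyond the scatter), which shows that the step seen there does not carry over to this single exchange on the core of compound 1, although the two cases differ both in the core and in the number of groups exchanged. No measurement at hand accounts for the difference between these two steps.

Still open, going by these compounds, is whether this position responds to any other group, such as an amine, a hydroxyl or a longer chain like ethoxy, or whether methyl and methoxy are simply alike here. The read-out at a single concentration also leaves open whether compound 1 and compound 4 would separate at other concentrations or in other plant species.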